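The source may report more compounds than this note shows. Statements on the series, on what has been measured and on what is new or still open speak of the compounds shown alone.

Measured in a functional assay on HT-29 cells (Homo sapiens); a lower number here means that less compound is needed, a higher number that more compound is needed for the effect:
- Compound 1 `NC(=O)Nc1sc(-c2ccc(C(=O)N3CCCCC3)cc2)cc1C(=O)N[C@H]1CCCNC1`: 130 nM
- Compound 2 `CN(C)C(=O)c1ccc(-c2cc(C(=O)N[C@H]3CCCNC3)c(NC(N)=O)s2)cc1`: 320 nM

Compound 2, at 320 nM, has the higher of the two numbers. Compound 3 `CS(=O)(=O)c1ccc(-c2cc(C(=O)N[C@H]3CCCNC3)c(NC(N)=O)s2)cc1` alters it in one place: methylsulfonyl in place of dimethylcarbamoyl on an aromatic carbon. In words, methylsulfonyl stands in place of dimethylcarbamoyl on an aromatic carbon. For the measured compounds named here, the only measured step is a 2.5-fold higher number from compound 1 to compound 2 (0.39 log units; beyond the scatter), a modest one, where dimethylamino replaces piperidin-1-yl on a carbonyl carbon. That is a different change, so it serves only as a rough guide to size. A similarly modest rise is expected, though a fall remains possible. The expected step is a 1.3-fold higher number from compound 2 to compound 3 (0.10 log units; within the scatter). For compound 3 the estimated value is 400 nM, with an expected range of 130 nM to 1200 nM.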

Compound 3, half-maximal effective concentration: 200 nM
Beside the measured number, compound 3's estimate is 2.0-fold (0.30 log units) above it; low and high end bracket the measured number.
By their numbers in this assay, from the lowest: compounds 1, 3 and 2 (each within the scatter of the next, the first and the last beyond it).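

In this assay, putting methylsulfonyl in place of dimethylcarbamoyl on this aromatic carbon gives a 1.6-fold lower number from compound 2 to compound 3 (0.20 log units; within the scatter), and putting it in place of (piperidin-1-yl)carbonyl gives a 1.5-fold higher number from compound 1 to compound 3 (0.19 log units; within the scatter). Both steps lie within the scatter, so among these compounds a carbonyl-linked amide at this position can be exchanged for methylsulfonyl with no clear shift in the number. Nothing available explains this result. As far as these compounds go, whether an amine or a carboxylic acid at this position would also stay in this range remains open.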